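The compounds below may be only part of what the source reports. "The series", "measured", "known", "first", "only" and "open" are said of these compounds alone.

Measured compounds:
Compound 1 `CN1CCN(Cc2ccc(NC(=O)c3ccc(OCCCCl)c(S(N)(=O)=O)c3)cc2C(F)(F)F)CC1` — 5470 nM
Compound 2 `CCC(=O)Nc1cc(C(=O)Nc2ccc(OC)cc2)ccc1OC(C)C` — 113000 nM

Both numbers come from a toxicity assay on Huh-7.5 cells (Homo sapiens) for inhibition, read by MTT assay, with a stated time of 96 h; on this read-out higher numbers stand for lower toxicity in this test and lower numbers for higher toxicity in this test. Compound 1 holds the lower of the two, and compound 2 sits well above it, the gap being far outside the usual scatter. The two differ in many places, so nothing can be drawn from that gap about any single group; it only shows that compound 1 is the more toxic of the pair in this assay.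

Compound 3 `CN1CCN(Cc2ccc(NC(=O)c3ccc(OCCCCl)c(Cl)c3)cc2C(F)(F)F)CC1` has not yet been measured. It keeps the whole of compound 1 except at one aromatic carbon, where the change is chloro in place of sulfamoyl on an aromatic carbon. Among the compounds with values here, no measured pair in the set isolates this change, so the size of its effect in this assay is not known from the data. The expectation is a small shift, on the order of the scatter or slightly toward a lower number. Compound 3 is estimated at 4000 nM, with a range from 1500 nM to 12000 nM. This estimate corresponds to an expected step of a 1.4-fold lower number from compound 1 to compound 3 (0.14 log units; within the scatter).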

Compound 3, half-maximal cytotoxic concentration: 4100 nM
Compound 3: middle estimate off by 1.0-fold (0.01 log units), on the low side; measured number inside the range.
By their numbers in this assay, from the lowest: compounds 3 and 1 (each within the scatter of the next); then compound 2.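

Chloro in place of sulfamoyl gives a 1.3-fold lower number from compound 1 to compound 3 (0.13 log units; within the scatter) in this assay at this aromatic carbon, ortho to a 3-chloropropoxy group and meta to a large group. Within the data shown here, this is the first comparison that isolates a single place, and it shows that the read-out does not separate the two compounds, even though the 4 heavy atoms of sulfamoyl, with its hydrogen-bond donor and acceptors, give way to a single chlorine with neither, so toxicity at this level in this test does not depend on sulfamoyl being at this carbon. The numbers alone offer no measured basis for explaining this outcome.

Going by these compounds, whether the same holds for other groups on this carbon, such as fluoro, methoxy, a nitrile or a carboxylic acid, or for plain hydrogen, remains open. Also open is whether the result carries over to the 3-chloropropoxy group itself, for example with a hydroxyl at the chain end in place of chlorine or with a shorter chain, since the compounds shown hold that group fixed across this step.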